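Chloro to Methyl: What to Expect for Enzyme Inhibition

The source may report more compounds than this note shows. Statements on the series, on what has been measured and on what is new or still open speak of the compounds shown alone.

Measured compounds:
compound 1 `O=C(Oc1ccccc1)N1CCC(CCn2ccc3cccc(F)c32)CC1` with 52 nM
compound 2 `O=C(Oc1ccccc1)N1CCC(CCn2ccc3cc(Cl)ccc32)CC1` with 410 nM

In an assay on microsomes from brain for inhibition of Fatty-acid amide hydrolase 1 (Rattus norvegicus), read by HPLC, with a stated time of 60 min (a higher number here means a weaker inhibitor, a lower number a stronger inhibitor), compound 1 gives 52 nM, while compound 2 gives 410 nM. Of these two numbers, compound 2 stands highest, and its gap to compound 1 lies beyond the usual scatter, so compound 2 is the weaker inhibitor of the pair.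

Compound 3 `Cc1ccc2c(ccn2CCC2CCN(C(=O)Oc3ccccc3)CC2)c1` differs from compound 2 in a single place: methyl in place of chloro on an aromatic carbon. Both groups are small, carry no hydrogen-bond donors or acceptors and sit on the same aromatic carbon of the shared core. Among the measured compounds shown here, no pair of measured compounds shows this exchange, so there is no directly comparable step. A modest shift of a 1.4-fold lower number from compound 2 to compound 3 (0.14 log units; within the scatter) is expected, a step that may not rise beyond the scatter. Compound 3 is therefore estimated at 300 nM, with a plausible range from 100 nM to 1000 nM.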

Compound 3, half-maximal inhibitory concentration: 700 nM
For compound 3 the middle estimate is 2.3-fold (0.37 log units) below the measured one; the range from low to high includes it.
By their numbers in this assay, from the lowest: compound 1; then compounds 2 and 3 (each within the scatter of the next).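

In this assay, exchanging chloro for methyl on this aromatic carbon, meta to a fused ring and para to a fused ring, gives a 1.7-fold higher number from compound 2 to compound 3 (0.23 log units; within the scatter), so at this position the two groups cannot be told apart by this read-out. Compound 1 and compound 2 differ in more than one place and offered no such direct reading of a single exchange. No measurement among the data explains why this exchange leaves the number within the scatter.

On these data alone, whether a plain hydrogen, an amine, a carboxylic acid or a longer chain on the same carbon would also stay within the scatter remains open. As far as these compounds go, it is equally open whether methyl and chloro would match on the carbon that carries fluoro in compound 1.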